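Butoxycarbonyl to isopropoxycarbonyl: cytotoxicity notes on the series

This account rests on a few compounds, and the source may have more. Where it says the series, first, only, none or still open, it means among the compounds named here.

compound 1 `CCCCOC(=O)OCC(CO)CCn1cnc2cnc(N)nc21` — > 500000 nM
compound 2 `CCCOC(=O)OCC(CO)CCn1cnc2cnc(N)nc21` — > 500000 nM

In a functional assay on Vero cells (Chlorocebus sabaeus) for cytotoxicity (a higher number here means that more compound is tolerated, a lower number that less compound is tolerated), compound 1 gives > 500000 nM, which is a limit of the assay and not a number. Compound 2 gives > 500000 nM in this assay, again only a limit. Going by the values given here, the single measured step, a step that the two limits leave unreadable from compound 1 to compound 2, therefore has no readable size. Both measured values sit at the limit of > 500000 nM in this assay, at which 2 of the 2 values shown sit, so compound 1 stands only at a limit, with no number to place it relative to compound 2.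

Compound 3 `CC(C)OC(=O)OCC(CO)CCn1cnc2cnc(N)nc21` differs from compound 1 by isopropyl in place of butyl on an oxygen next to a carbonyl group, that is butoxycarbonyl to isopropoxycarbonyl. Among the compounds with values here, no measured step bears on this change with a readable size; the only one available is unreadable at both ends, so no direction beyond the scatter is expected.

Compound 3 is expected to give 600000 nM, in the range 300000 nM to 2000000 nM, and most probably again only a limit. The step this estimate means, a step that the limit leaves unreadable from compound 1 to compound 3, is expected to be none beyond the scatter.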

Compound 3, half-maximal cytotoxic concentration: > 500000 nM
Compound 3 gave a limit, no number (the forecaster's own chance of this, stated with the estimate: 85%); the middle value lies beyond the limit too.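

No step can be read among compound 1, compound 2 and compound 3, because each value is a limit of the assay and not a number: the limit of > 500000 nM in this assay, at which 3 of the 3 values shown sit.

In this assay the compounds shown leave open whether butyl, propyl and isopropyl differ at all.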